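The source may report more compounds than this note shows. Statements on the series, on what has been measured and on what is new or still open speak of the compounds shown alone.

The measured compounds are these. Compound 1 `COC(=O)c1ccc(OCc2oc(-c3ccccc3OC)nc2C)cc1` was tested in an assay on cells for antagonist activity at vitamin D3 receptor (Homo sapiens), read by a luciferase reporter (on this read-out lower numbers stand for stronger inhibition and higher numbers for weaker inhibition), where compound 1 gives 17900 nM. Compound 2 `COC(=O)c1ccc(OCc2oc(-c3cccc(OC)c3)nc2C)cc1` gives 8890 nM. Compound 3 `COc1ccccc1-c1nc(C)c(COc2cccc(C(=O)O)c2)o1` gives > 100000 nM, which is a limit of the assay and not a number.

Compounds 1 and 2 share a core and differ in one group, as set out here: 3-methoxyphenyl in place of 2-methoxyphenyl on an aromatic carbon. The measured step is a 2.0-fold lower number from compound 1 to compound 2 (0.30 log units; within the scatter). The cores of compound 1 and compound 3 differ in several places, and that difference is not broken down here. For compound 3 only the limit is known, as shown by the limit of > 100000 nM in this assay, at which 1 of the 3 values shown sits.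

Compound 4 `COc1cccc(-c2nc(C)c(COc3cccc(C(=O)O)c3)o2)c1` is not yet measured. It differs from compound 3 in this way: 3-methoxyphenyl in place of 2-methoxyphenyl on an aromatic carbon. The place of the change is the same, word for word, as for the step from compound 1 to compound 2, so this is the same change made on the other core. That earlier step fell within the usual scatter of repeated measurements, so there is no reason from the data to expect this change to move compound 4 far from compound 3. Compound 4 is therefore expected to sit near the limit as well, with an estimated step of a number no higher from compound 3 to compound 4 (the limit leaves the size open). In this assay compound 4 is estimated at about 100000 nM, most likely between 40000 nM and 300000 nM.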

Compound 4, half-maximal inhibitory concentration: 33100 nM
Beside the measured number, compound 4's estimate is 3.0-fold (0.48 log units) above it; the whole stated range lies above it.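

In this assay, 3-methoxyphenyl in place of 2-methoxyphenyl on the core of compound 3 gives an at least 3.0-fold lower number from compound 3 to compound 4 (0.48 log units; beyond the scatter). Set beside the same change on the core of compound 1, this gives two steps that can be compared only loosely: the same change on two cores in this assay, a 2.0-fold lower number (0.30 log units; within the scatter) from compound 1 to compound 2 and an at least 3.0-fold lower number (0.48 log units; beyond the scatter) from compound 3 to compound 4; the limit leaves it open whether they differ

So the change clearly lowers the number on one core only, and the data do not show whether it is worth more on that core than on the other, since compound 3 has a limit of the assay and not a number: the limit of > 100000 nM in this assay, at which 1 of the 4 values shown sits.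

From the compounds shown here alone, the cores of compound 1 and compound 3 differ in several places at once, so what the methyl ester or the carboxylic acid does on its own stays open, as does whether an amide in their place would fit the same pattern. Going by these compounds, only the 2-methoxyphenyl and 3-methoxyphenyl groups appear here, so it also remains open how a plain phenyl, or a phenyl carrying a chlorine or a hydroxyl group instead of the methoxy group, would behave on either core.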